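Macrocycle side-chain swap: amine replaced by amide

This account rests on a few compounds, and the source may have more. Where it says the series, first, only, none or still open, it means among the compounds named here.

Of the compounds shown here, two have been tested so far in a functional assay on SMMC-7721 cells (Homo sapiens) for antiproliferative activity, read by MTT assay, with a stated time of 48 h; a lower number here means a stronger inhibitor, a higher number a weaker inhibitor. Compound 2 `CC(C)=CCC[C@]1(C)/C=C/[C@@H](OC(=O)C=C(C)C)[C@](C)(O)/C=C/C(=O)/C(CN(C(C)C)C(C)C)=C\C1` is the stronger of the pair; in this assay compound 2 gives 340 nM. Compound 1 `CO[C@]1(C)/C=C/C(=O)/C(CO)=C\C[C@](C)(CCC=C(C)C)/C=C/[C@H]1OC(=O)C=C(C)C` carries a hydroxymethyl group and a methoxy group where compound 2 carries a (diisopropylamino)methyl group and a hydroxy group. In this assay compound 1 gives 15800 nM, a clearly weaker result that lies well outside the usual scatter. These two compounds differ in more than one place. The gap between them cannot be pinned to a single change.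

Compound 3 `CCN(CC)C(=O)/C1=C/C[C@](C)(CCC=C(C)C)/C=C/[C@@H](OC(=O)C=C(C)C)[C@](C)(O)/C=C/C1=O` has not yet been measured. It differs from compound 2 in one place: diethylcarbamoyl in place of (diisopropylamino)methyl on a double-bonded ring carbon. The amine that sits on the ring in compound 2 is thus gone, and an amide takes its position. Since compound 2 gives 340 nM and the amine-free compound 1 gives 15800 nM, a loss of activity is expected for compound 3, estimated as a 12-fold higher number from compound 2 to compound 3 (1.07 log units; beyond the scatter). The estimate for compound 3 in this assay is 4000 nM, with an expected range from 1000 nM to 16000 nM.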

Compound 3, half-maximal inhibitory concentration: 13800 nM
Estimate against measurement, compound 3: 3.5-fold (0.54 log units) below, within the range that was stated.
By their numbers in this assay, from the lowest: compound 2; then compounds 3 and 1 (each within the scatter of the next).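

Swapping (diisopropylamino)methyl for diethylcarbamoyl on a double-bonded ring carbon, with the rest of the molecule unchanged, gives a 41-fold higher number from compound 2 to compound 3 (1.61 log units; beyond the scatter) in this assay. Among the compounds shown here, this is the first change that can be tied to one place, and it shows that activity in this assay depends strongly on the group at this ring carbon, even though the two groups have matching counts of nitrogen atoms, hydrogen-bond donors, hydrogen-bond acceptors and net charge, and nearly matching heavy-atom counts. Nothing measured here explains why the step is so large.

This single swap also alters two features together, adding a carbonyl directly on the ring carbon and replacing the isopropyl groups on the nitrogen with ethyl groups, so the compounds shown cannot say which feature matters more. A (diethylamino)methyl group at the same ring carbon would separate these two features, while a piperidin-1-ylmethyl group or a carboxylic acid there would test how far the result extends to other kinds of group.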